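Aryl swap on the shared core: solubility notes

The compounds below may be only part of what the source reports. "The series", "measured", "known", "first", "only" and "open" are said of these compounds alone.

Compound 1, `Cc1ccccc1-c1nc(CN2CCC(C(=O)NCCCN3CCCC(CC(C)C)C3)CC2)c(C)o1`, in a physicochemical assay for solubility, in phosphate buffer, measured as kinetic solubility, at pH 7.4 (on this read-out higher numbers stand for higher solubility and lower numbers for lower solubility), gives 54.9 ug/mL.
Compound 2, `Cc1oc(-c2c(Br)cccc2Br)nc1CN1CCC(C(=O)NCCCN2C[C@H](C)C[C@H](C)C2)CC1`, gives 62.4 ug/mL.
Compound 3, `Cc1ccccc1-c1nc(CN2CCC(C(=O)NCCCN3CC4CCCC(C4)C3)CC2)c(C)o1`, gives > 71 ug/mL, which is a limit of the assay and not a number.

Of the two numbers reported, that of compound 2 is the higher, with compound 1 nearest and within the usual scatter of it, so the two cannot be told apart. Going by the values given here, the only measured step, an at least 1.2-fold higher number from compound 1 to compound 3 (0.11 log units; that floor lies within the scatter), changes the group on the chain beyond the amide nitrogen and ends at the limit described by the limit of > 71 ug/mL in this assay, at which 1 of the 3 values shown sits; it does not touch the aryl group on the core.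

Compound 4, `COc1ccc(-c2nc(CN3CCC(C(=O)NCCCN4C[C@H](C)C[C@H](C)C4)CC3)c(C)o2)cc1OC`, differs from compound 2 at that aryl group: 3,4-dimethoxyphenyl in place of 2,6-dibromophenyl on an aromatic carbon. Among the compounds with values here, no measured step bears on this exchange, so nothing in the set fixes its size or direction. Working from compound 2 alone, the expected step is a 1.2-fold higher number from compound 2 to compound 4 (0.06 log units; within the scatter), and compound 4 is estimated at 72 ug/mL, in the range 45 ug/mL to 115 ug/mL. Since one of the three readings already sits at the limit given by the limit of > 71 ug/mL in this assay, at which 1 of the 3 values shown sits, a limit rather than a number is a real possibility for compound 4.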

Compound 4, solubility: > 76 ug/mL
Compound 4 gave a limit, no number; the forecaster's own chance of this, stated with the estimate: 50%; middle value at least 1.0-fold (0.02 log units) away from the limit.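

Compound 4 stands as a limit and not a number in this assay: the limit of > 76 ug/mL in this assay, at which 1 of the 4 values shown sits.

Going by these compounds alone, this gives the first reading at the aryl position, the aromatic carbon next to the ring nitrogen and next to the ring oxygen, where the earlier step touched only the chain beyond the amide nitrogen. Exchanging the two aryl groups gives an at least 1.2-fold higher number from compound 2 to compound 4 (0.08 log units; that floor lies within the scatter), so the floor of this step does not separate compound 2 from compound 4, and the true size of the step cannot be read from these values. The exchange replaces a group carrying two bromine atoms and 0 hydrogen-bond acceptors with one carrying two methoxy groups and 2 hydrogen-bond acceptors, and the reading for compound 4 still ends at a limit.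

The compounds shown leave open how an unsubstituted phenyl, a single methoxy group or a carboxylic acid on the aryl ring would read at this position. They also leave open whether 3,4-dimethoxyphenyl gives a similar reading when paired with the chain group of compound 1 or compound 3.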